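Chloro on an inactive pyridyl amide

The source may report more compounds than this note shows. Statements on the series, on what has been measured and on what is new or still open speak of the compounds shown alone.

Measured in a functional assay on HO8910 cells (Homo sapiens) for inhibition, read by MTT assay, with a stated time of 24 h, tested at 1 ug/mL; a higher number here means more inhibition of growth at the concentration tested, a lower number less inhibition of growth:
- compound 1 `O=C(CCCCC1CCSS1)Nc1ccc(Cl)cn1`: 2.1%
- compound 2 `O=C(CCCCC(S)CCS)Nc1ccccc1`: 6.38%
- compound 3 `O=C(CCCCC(S)CCS)Nc1ccccn1`: "not active" (no number reported)

In this assay compound 3 has no number, and its result is recorded only as "not active" (no number reported). Compound 4 `O=C(CCCCC(S)CCS)Nc1ccc(Cl)cn1` has not yet been measured. The step chloro in place of hydrogen on an aromatic carbon puts chloro in place of hydrogen on an aromatic carbon. Going by the values given here, no measured pair shows this change alone, so its size cannot be read directly. Compound 1, which also carries chloro, gives only 2.1%, and compound 2 gives 6.38%. A small upward step at most is therefore expected, with none beyond the scatter. For compound 4 the expected value is 5%, with an estimated range of 0% to 15%.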

Compound 4, percent growth inhibition at one concentration: "not active" (no number reported)
No number was reported for compound 4, and the estimate cannot be compared.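

Neither compound 3 nor compound 4 has a number in this assay, so no step can be read between them. Whether chloro in place of hydrogen changes growth inhibition stays open, and no evidence shown bears on this result.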